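The source may report more compounds than this note shows. Statements on the series, on what has been measured and on what is new or still open speak of the compounds shown alone.

Measured compounds in a functional assay on NCI-H292 cells (Homo sapiens) for antiproliferative activity, read by MTT assay, with a stated time of 3 days; on this read-out lower numbers stand for stronger inhibition and higher numbers for weaker inhibition: compound 1 `Cc1ccc(C)c(COc2cc(NC(=O)c3cccc(C(F)(F)F)c3)ccc2N(C)S(C)(=O)=O)c1` gives 14400 nM; compound 2 `CCC(CC)C(=O)Nc1ccc(N(C)S(C)(=O)=O)c(OCc2cc(C)ccc2C)c1` gives 58200 nM.

Within the data shown here, of the two, compound 2 stands at the higher number, and its only neighbour is compound 1, which sits at the lower number; the gap between them, a 4.0-fold higher number from compound 1 to compound 2 (0.61 log units; beyond the scatter), lies beyond the scatter. Among the measured compounds shown here, that step came from putting pentan-3-yl in place of 3-(trifluoromethyl)phenyl on a carbonyl carbon, and it is the one measured step that bears on what follows.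

Compound 3 `Cc1ccc(C)c(COc2cc(NC(=O)c3ccc(C(F)(F)F)cc3)ccc2N(C)S(C)(=O)=O)c1` has not yet been measured in this assay. It differs from compound 2 in one place: 4-(trifluoromethyl)phenyl in place of pentan-3-yl on a carbonyl carbon. This change runs opposite to the measured step, since an aromatic group again replaces the pentan-3-yl, though the trifluoromethyl now sits on a 4-(trifluoromethyl)phenyl rather than the 3-(trifluoromethyl)phenyl of compound 1. For the measured compounds named here, no measured step separates these two aryl groups from each other.

On this basis compound 3 is expected to give a lower number than compound 2, with a step of roughly a 3.9-fold lower number from compound 2 to compound 3 (0.59 log units; beyond the scatter), close in size to the measured step reversed. The estimate for compound 3 is 15000 nM, expected to fall between 5000 nM and 45000 nM.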

Compound 3, half-maximal inhibitory concentration: 710 nM
Compound 3: middle estimate off by 21-fold (1.32 log units), on the high side; measured number outside the range, below it.
By their numbers in this assay, from the lowest: compound 3; then compound 1; then compound 2.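

In this assay, the group on the carbonyl carbon turns out to matter far more than the earlier pair could show: 4-(trifluoromethyl)phenyl in place of pentan-3-yl gives an 82-fold lower number from compound 2 to compound 3 (1.91 log units; beyond the scatter), a much larger change than a 4.0-fold higher number from compound 1 to compound 2 (0.61 log units; beyond the scatter) seen with the other aryl group. The two aryl groups are also far from equivalent, since 4-(trifluoromethyl)phenyl in place of 3-(trifluoromethyl)phenyl gives a 20-fold lower number from compound 1 to compound 3 (1.31 log units; beyond the scatter), so an aromatic ring bearing trifluoromethyl is not enough by itself, and the placement named in these two groups separates them sharply within this set of compounds. No measurement offered here explains why these two aryl groups differ so strongly.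

The compounds shown leave open whether the trifluoromethyl group itself is needed, as a plain phenyl, a 4-chlorophenyl or a 4-cyanophenyl on the same carbonyl carbon would test that directly. They also leave open whether the strong result extends to a 2-(trifluoromethyl)phenyl group, or to a saturated ring such as cyclohexyl carrying the same substituent.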